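From a dimethylamino chain to piperazin-1-yl

The source may hold more compounds than are shown below. What is called first, only, known or untested is meant among the compounds shown, and "the series" means these compounds.

In a functional assay on P388 cells (Mus musculus) for cytotoxicity (a higher number here means a weaker inhibitor, a lower number a stronger inhibitor), compound 1 `CCCCN1C(=O)c2cccc3c2c(cc2c4ccccc4oc32)C1=O` gives only a limit, not a number: > 100000 nM. Within the data shown here, compound 2 `CN(C)CCCN1C(=O)c2cccc3c2c(cc2c4ccccc4oc32)C1=O` gives 170 nM, the only true number so far, so it cannot yet be ranked against any other measured value.

Compound 3 `O=C1c2cccc3c2c(cc2c4ccccc4oc32)C(=O)N1CN1CCNCC1` changes the side chain of compound 2 again: piperazin-1-yl in place of 2-(dimethylamino)ethyl on a saturated chain carbon bound to an amide-type nitrogen in a ring. In words, piperazin-1-yl stands in place of 2-(dimethylamino)ethyl on a saturated chain carbon bound to an amide-type nitrogen in a ring.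

Among the measured compounds shown here, one measured step bears on this, the large at least 580-fold lower number from compound 1 to compound 2 (2.76 log units; beyond the scatter), which came with dimethylamino in place of methyl on the chain. Compound 3 gives up that dimethylamino group but carries piperazin-1-yl, so a clear loss is expected, though a smaller one than that step. The expected change is a 5.9-fold higher number from compound 2 to compound 3 (0.77 log units; beyond the scatter), towards a higher number in this assay. Compound 3 is estimated at 1000 nM, within an expected range of 150 nM to 15000 nM.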

Compound 3, half-maximal inhibitory concentration: 580 nM
Compound 3: the middle estimate sits 1.7-fold (0.24 log units) above what was measured, within the range that was stated.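

In this assay, the basic-looking dimethylamino end is not the only chain end that works at this position: swapping 3-(dimethylamino)propyl for (piperazin-1-yl)methyl costs only a modest amount, a 3.4-fold higher number from compound 2 to compound 3 (0.53 log units; beyond the scatter). Most of the gain over the chain with no nitrogen survives the swap, an at least 170-fold lower number from compound 1 to compound 3 (2.23 log units; beyond the scatter), so an open-chain amine and a ring amine both give far stronger numbers than the plain chain. That second step has no exact size, as compound 1 gives only a limit: the limit of > 100000 nM in this assay, at which 1 of the 3 values shown sits.

The compounds shown do not separate the effect of the piperazine ring from that of the link holding it to the amide-type nitrogen. Open questions include how a 3-(piperazin-1-yl)propyl chain would compare, which would pair the ring with the chain of compound 2, and how a morpholin-4-yl end would fare.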